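Swapping 3-chlorophenyl for 4-hydroxyphenyl on the shared core

The compounds below may be only part of what the source reports. "The series", "measured", "known", "first", "only" and "open" are said of these compounds alone.

Values in a functional assay on CCRF-CEM cells (Homo sapiens) for inhibition, read by MTT assay, with a stated time of 72 h (on this read-out lower numbers stand for stronger inhibition and higher numbers for weaker inhibition), so far:
Compound 1 `COc1cc(NC(C)CCCNC(=O)NNC(=O)Nc2ccc(F)cc2)c2ncccc2c1` gives 118000 nM
Compound 2 `COc1cc(NC(C)CCCNC(=O)NNC(=O)Nc2ccc(Cl)cc2)c2ncccc2c1` gives 108000 nM
Compound 3 `COc1cc(NC(C)CCCNC(=O)NNC(=O)Nc2cccc(Cl)c2)c2ncccc2c1` gives 81000 nM

These three numbers sit close together, and compound 3 stands level with the other two. The steps that reach it are a 1.5-fold lower number from compound 1 to compound 3 (0.16 log units; within the scatter) and a 1.3-fold lower number from compound 2 to compound 3 (0.12 log units; within the scatter) and neither separates it from its neighbours. Replacing fluoro with chloro on an aromatic carbon gives a 1.1-fold lower number from compound 1 to compound 2 (0.04 log units; within the scatter) and that step is equally small.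

Compound 4 `COc1cc(NC(C)CCCNC(=O)NNC(=O)Nc2ccc(O)cc2)c2ncccc2c1` keeps the shared core and differs only on the amide-type nitrogen, where 4-hydroxyphenyl takes the place of 3-chlorophenyl (4-hydroxyphenyl in place of 3-chlorophenyl on an amide-type nitrogen). All three measured steps only exchange one chloro- or fluoro-bearing phenyl group for another. Going by the values given here, none of the measured compounds carries a 4-hydroxyphenyl group, so the evidence is indirect and the range must stay wide.

On that basis, no step beyond the scatter is expected in this assay and no firm direction can be called. The estimated step is a 1.2-fold higher number from compound 3 to compound 4 (0.09 log units; within the scatter) and it should be read as no real change. Compound 4 is estimated at 100000 nM with an expected range from 40000 nM to 200000 nM in this assay once it is measured.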

Compound 4, half-maximal inhibitory concentration: 111000 nM
Compound 4: middle estimate off by 1.1-fold (0.05 log units), on the low side; measured number inside the range.
By their numbers in this assay, from the lowest: compounds 3, 2, 4 and 1 (each within the scatter of the next).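

In this assay, going by these compounds alone, this is the first group on this amide-type nitrogen whose ring carries a hydroxy rather than a halogen, bringing in a hydrogen-bond donor and a hydrogen-bond acceptor that 3-chlorophenyl lacks, and the exchange gives a 1.4-fold higher number from compound 3 to compound 4 (0.14 log units; within the scatter) and so no real change. The comparisons that keep the substituent in the 4-position tell the same story, since hydroxy in place of chloro gives a 1.0-fold higher number from compound 2 to compound 4 (0.01 log units; within the scatter) and hydroxy in place of fluoro gives a 1.1-fold lower number from compound 1 to compound 4 (0.03 log units; within the scatter), which extends the flat picture from halogen swaps to a change of substituent type across these four compounds, with none of them going against it. Nothing available here explains why the number stays put.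

From the compounds shown here alone, all four compounds keep a substituted phenyl group at this spot, so it remains open whether an amine or a carboxylic acid on that ring, or a longer chain in place of the ring, would move the number beyond the scatter. Changes to the shared core, or to the chain that links it to the carbonyl groups, also remain open, as every compound here carries both unchanged.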